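Thiophene in place of the hydroxypyrimidine on the sulfoxide arm

The source may hold more compounds than are shown below. What is called first, only, known or untested is meant among the compounds shown, and "the series" means these compounds.

For the measured compounds named here, compound 1 `Cc1cc(O)nc(C[S+]([O-])C(c2ccccc2)c2ccccc2)n1` stands highest of the three numbers so far: in an assay on HEK293 cells for inhibition of sodium-dependent dopamine transporter (Homo sapiens), read by scintillation counting, with stated times of 5 min and 1 min (on this read-out lower numbers stand for stronger inhibition and higher numbers for weaker inhibition), compound 1 gives 109000 nM. Compound 2 `[O-][S+](Cc1nc(O)cc(C(F)(F)F)n1)C(c1ccccc1)c1ccccc1` gives 40400 nM, the nearest neighbour, and compound 3 `Cc1ccc(C(c2ccc(C)cc2)[S+]([O-])Cc2cccs2)cc1` gives 5800 nM, the furthest. Going by the values given here, the one clean step recorded, a 2.7-fold lower number from compound 1 to compound 2 (0.43 log units; beyond the scatter), changes only a substituent on the aromatic part of the chain and leaves the shared core untouched.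

Compound 4 `[O-][S+](Cc1ccsc1)C(c1ccccc1)c1ccccc1` is the next question. It differs from compound 1 as follows: thiophen-3-yl in place of 4-hydroxy-6-methylpyrimidin-2-yl on a saturated chain carbon bound to a sulfur. Among the compounds with values here, no recorded step covers this exchange on its own. Compound 3 carries a thiophen-2-yl on that same chain carbon, but its two phenyl groups also carry methyls, so the gap between compound 1 and compound 3 cannot be split between the two changes; it shows only that a thiophene arm in this series can sit far below compound 1. That comparison, taken loosely, points to a clear drop in number for compound 4, larger than the step to compound 2 and possibly approaching compound 3.

Compound 4 is therefore expected to give 12000 nM, with a range of 3500 nM to 40000 nM. The expected step, a 9.1-fold lower number from compound 1 to compound 4 (0.96 log units; beyond the scatter), would be well beyond the scatter.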

Compound 4, half-maximal inhibitory concentration: 3000 nM
The estimate for compound 4 lay 4.0-fold (0.60 log units) above the measured number; measured number outside the range, below it.
By their numbers in this assay, from the lowest: compounds 4 and 3 (each within the scatter of the next); then compound 2; then compound 1.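

In this assay, for the compounds shown here, the whole arm on a saturated chain carbon bound to a sulfur proves a far larger lever than the one substituent change seen before: a 36-fold lower number from compound 1 to compound 4 (1.56 log units; beyond the scatter) is a large step, whereas a 2.7-fold lower number from compound 1 to compound 2 (0.43 log units; beyond the scatter) is a modest one. The result also shows that a low number at this position does not require the 4-hydroxy-6-methylpyrimidin-2-yl, since the thiophen-3-yl, with fewer heavy atoms, 0 hydrogen-bond donors and 1 hydrogen-bond acceptor, takes its place on an otherwise unchanged core. The exchange alters ring size, hetero atoms and donor and acceptor counts together, and no supporting measurement shows which of these differences accounts for the step.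

The compounds shown leave open whether the sulfur-containing ring itself matters or whether any small aromatic arm would serve, a question that a plain phenyl or a furan-3-yl on the same chain carbon would address. As far as these compounds go, the effect of the thiophene attachment point also stays open, as compound 3 carries thiophen-2-yl together with methyls on both phenyl groups, so its number cannot isolate that change.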